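This account rests on a few compounds, and the source may have more. Where it says the series, first, only, none or still open, it means among the compounds named here.

Working notes on the series.

In an assay on HEK293 cells for inhibition of 17-beta-hydroxysteroid dehydrogenase type 1 (Mus musculus), read by HPLC, tested at 500 nM, in the presence of a further agent that is not named here (on this read-out higher numbers stand for more inhibition at the one concentration tested (going by the name of the read-out) and lower numbers for less inhibition), compound 2 `O=C(c1ccc(-c2cccc(NS(=O)(=O)c3cccc(Cl)c3)c2)s1)c1cc(F)c(F)c(O)c1F` gives 28%. Compound 1 `O=C(c1ccc(-c2cccc(NS(=O)(=O)c3ccccc3)c2)s1)c1cccc(O)c1Cl` gives 26% in this assay, and compound 3 `O=C(c1ccc(-c2cccc(NS(=O)(=O)c3ccccc3)c2)s1)c1c(F)ccc(O)c1Cl` gives 25%; all three numbers sit within the scatter of one another, so compound 2 stands level with the other two on this read-out. Among the compounds with values here, the only single-point step measured so far is a number 1 percentage points lower from compound 1 to compound 3 (within the scatter), a change elsewhere on the shared core that left this assay unmoved beyond the scatter.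

Compound 4 `O=C(c1ccc(-c2cccc(NS(=O)(=O)c3ccc(F)cc3)c2)s1)c1cc(F)c(F)c(O)c1F` arises from compound 2 through (4-fluorophenyl in place of 3-chlorophenyl on a sulfonyl sulfur). Within the data shown here, no measured step touches the group on the sulfonyl sulfur; the change is therefore unanchored by the data, and the three measured values themselves span only a few points. The expectation for this assay is accordingly a step of a number 1 percentage points lower from compound 2 to compound 4 (within the scatter), not beyond the scatter. Compound 4 is expected to give 27% in this assay, with a range from 12% to 42%.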

Compound 4, a percentage reported as inhibition, at one concentration (the size of the read-out at that concentration, not a potency): 24%
Beside the measured number, compound 4's estimate is 3 percentage points above it, and the stated range covers the measured number.
By their numbers in this assay, from the lowest: compounds 4, 3, 1 and 2 (each within the scatter of the next).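

The group on the sulfonyl sulfur now has its first measured step: in this assay the exchange of 3-chlorophenyl for 4-fluorophenyl gives a number 4 percentage points lower from compound 2 to compound 4 (within the scatter), so compound 2 and compound 4 stand level on this read-out. At this position, then, one halogen-bearing phenyl can stand in for another on the core of compound 2 without a change that can be told from the scatter, though this rests on a single pair at a single concentration. Nothing measured on these compounds offers an explanation for this result.

Going by these compounds, whether an amine, a carboxylic acid on that phenyl ring, or an open alkyl chain in place of the ring would move the number beyond the scatter remains open. Also open, on these data alone, is whether the same exchange reads alike on the cores of compound 1 and compound 3.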